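This account rests on a few compounds, and the source may have more. Where it says the series, first, only, none or still open, it means among the compounds named here.

Measured so far in a functional assay on SEM cells (Homo sapiens) for cytotoxicity, with a stated time of 72 h; on this read-out lower numbers stand for an effect already at smaller amounts and higher numbers for an effect only at larger amounts of compound:
- Compound 1 `C=C[C@@](C)(/C=C/c1ccc(OCc2ccccc2)cc1)CCC=C(C)C`: > 36600 nM, a limit
- Compound 2 `C=C[C@@](C)(/C=C/c1ccc(Nc2ccc(OC)cc2)cc1)CCC=C(C)C`: > 36600 nM, a limit

Going by the values given here, compound 2 has no numerical value, only a limit, and the one other measured compound also sits at a limit, as the limit of > 36600 nM in this assay, at which 2 of the 2 values shown sit, shows. Compound 3 `C=C[C@@](C)(/C=C/c1ccc(Nc2ccc(F)c(F)c2)cc1)CCC=C(C)C` has 3,4-difluorophenyl in place of 4-methoxyphenyl on a nitrogen on an aromatic ring. Among the compounds with values here, the only measured step bearing on this change is a step that the two limits leave unreadable from compound 1 to compound 2. It offers no size to carry over, so no step beyond the scatter is expected in this assay, and no direction is favoured. The expectation rests on compound 2, whose reading of > 36600 nM is a limit. The step expected is an at least 1.2-fold lower number from compound 2 to compound 3 (0.08 log units; that floor lies within the scatter). For compound 3 the estimate is 30000 nM, with an expected range of 8000 nM to 50000 nM, and a further limit is the likeliest report.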

Compound 3, half-maximal effective concentration: > 36600 nM
Compound 3 gave a limit, no number; the forecaster's own chance of this, stated with the estimate: 70%; middle value at least 1.2-fold (0.08 log units) from the limit.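

Compound 1, compound 2 and compound 3 each give only a limit in this assay, so no step among them can be read: the limit of > 36600 nM in this assay, at which 3 of the 3 values shown sit.

Still open, on these data alone, is whether these three compounds differ at all in this assay, and whether the group on the nitrogen affects the result.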